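Taking the methylamino group off compound 2

The source may hold more compounds than are shown below. What is called first, only, known or untested is meant among the compounds shown, and "the series" means these compounds.

In a functional assay on K562 cells (Homo sapiens) for antiproliferative activity, read by CellTiter-Glo and CCK-8 assay, with a stated time of 72 h (on this read-out higher numbers stand for weaker inhibition of growth and lower numbers for stronger inhibition of growth), two compounds have been measured so far. Compound 1 (`Cc1ccc(NC(=O)c2cccc(C(F)(F)F)c2)cc1N1Cc2cnc(OC3CCNCC3)nc2N(C)C1=O`) gives 220 nM, while compound 2 (`CNc1nc(Nc2ccc(C)c([N+](=O)[O-])c2)ncc1C(=O)Nc1cc(NC(=O)c2cccc(C(F)(F)F)c2)ccc1C`) gives 52 nM, the lower of the two numbers, and the gap between them lies beyond the scatter. The two differ in more than one place, so their gap says nothing about any single change. Compound 3 (`Cc1ccc(NC(=O)c2cccc(C(F)(F)F)c2)cc1NC(=O)c1cnc(Nc2ccc(C)c([N+](=O)[O-])c2)nc1`) has not yet been measured. It departs from compound 2 through (hydrogen in place of methylamino on an aromatic carbon), with hydrogen in place of methylamino on an aromatic carbon. Among the compounds with values here, no measured pair shows this change, so the expectation is tentative. A higher number, meaning weaker inhibition of growth, is expected, with an estimated 5.8-fold higher number from compound 2 to compound 3 (0.76 log units; beyond the scatter) that would probably lie beyond the scatter. Compound 3 is estimated at 300 nM, with an expected range of 90 nM to 1000 nM.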

Compound 3, concentration for 50% growth inhibition: 380 nM
For compound 3 the middle estimate is 1.3-fold (0.10 log units) below the measured one, within the range that was stated.
By their numbers in this assay, from the lowest: compound 2; then compounds 1 and 3 (each within the scatter of the next).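

In this assay, within the data shown here, this pair gives the first direct reading of the position: hydrogen in place of methylamino on the aromatic carbon next to the ring nitrogen brings a 7.3-fold higher number from compound 2 to compound 3 (0.86 log units; beyond the scatter). Within this pair, growth inhibition is therefore stronger with methylamino on this carbon than with hydrogen, which compound 1 could not show, since it differs from compound 2 in more than one place. Nothing measured here accounts for the size or direction of this step.

The reading rests on a single pair, so it cannot say how the same change would behave on another core. From the compounds shown here alone, it also remains open whether an ethylamino, a dimethylamino or a methoxy group on this carbon would give a number closer to that of compound 2 or to that of compound 3.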